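The source may hold more compounds than are shown below. What is called first, only, known or untested is meant among the compounds shown, and "the series" means these compounds.

Among the measured compounds shown here, in a functional assay on KB cells (Homo sapiens) for antiproliferative activity, read by sulforhodamine B assay, with a stated time of 3 days (on this read-out higher numbers stand for an effect only at larger amounts of compound and lower numbers for an effect already at smaller amounts), compound 2 `CCC1=C(O)c2c(oc(-c3cccc(C)c3C)cc2=O)C(CC)(CC)C1=O` gives 3.1 uM, the only true number so far. Compound 1 `CCC1=C(O)c2c(oc(-c3ccc(SC)cc3)cc2=O)C(CC)(CC)C1=O` gives > 52.1 uM, which is a limit of the assay and not a number. The comparison therefore rests on (the limit of > 52.1 uM in this assay, at which 1 of the 2 values shown sits).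

Compound 3 `CCC1=C(O)c2c(oc(-c3ccc(F)c(C)c3)cc2=O)C(CC)(CC)C1=O` keeps the shared core and changes one group: 4-fluoro-3-methylphenyl in place of 2,3-dimethylphenyl on an aromatic carbon. Here 4-fluoro-3-methylphenyl stands in place of 2,3-dimethylphenyl, on an aromatic carbon next to the ring oxygen.

For the measured compounds named here, one measured step bears on this same place, and it was large: an at least 16-fold lower number from compound 1 to compound 2 (1.22 log units; beyond the scatter). In that step, 2,3-dimethylphenyl replaced 4-(methylsulfanyl)phenyl. The new group in compound 3 is a different one again, so that step can only serve as a rough guide, and a repeat of its full size is not expected.

A moderate rise in the number is expected, an estimated 2.3-fold higher number from compound 2 to compound 3 (0.35 log units; beyond the scatter). For compound 3 the estimate is 7 uM, with an expected range from 2 uM to 30 uM.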

Compound 3, concentration for half-maximal effect: 40.5 uM
Compound 3: the middle estimate sits 5.8-fold (0.76 log units) below what was measured; the measured number lies above the stated range.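

In this assay, the aromatic carbon next to the ring oxygen proves sensitive even to an exchange between two groups of 8 heavy atoms, each one six-membered aromatic ring with no hydrogen-bond donors or acceptors: a 13-fold higher number from compound 2 to compound 3 (1.12 log units; beyond the scatter). Compound 2 now has a step beyond the scatter to each other compound shown, so its low number depends on 2,3-dimethylphenyl and not on the shared core alone. No order can be read between the other two, an at least 1.2-fold lower number from compound 1 to compound 3 (0.10 log units; that floor lies within the scatter), and that comparison rests on a limit: the limit of > 52.1 uM in this assay, at which 1 of the 3 values shown sits.

Which feature of 2,3-dimethylphenyl matters remains open. So does whether an amine or a carboxylic acid at this carbon, in place of the substituted phenyl groups, would keep or lose the effect on these cells.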